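Isopropoxy for methyl on the shared core

This account rests on a few compounds, and the source may have more. Where it says the series, first, only, none or still open, it means among the compounds named here.

Compound 1 `CCSc1nn2cc(-c3cc4ccccc4o3)nc2s1` has no result in an assay for antagonist activity at proteinase-activated receptor 4 (Homo sapiens), with stated times of 5 min, 50 s and 15 min, in the presence of a further agent that is not named here (on this read-out lower numbers stand for stronger inhibition and higher numbers for weaker inhibition), and stands as "not determined" (no result reported). Compound 2 `Cc1nn2cc(-c3cc4ccccc4o3)nc2s1` gives only a limit in this assay, > 30000 nM. That value is the limit of > 30000 nM in this assay, at which 1 of the 2 values shown sits, so compound 2 sits at the edge of the measurable range and no ranking of it is possible. Compound 3 `CC(C)Oc1nn2cc(-c3cc4ccccc4o3)nc2s1` differs from compound 2 by isopropoxy in place of methyl on an aromatic carbon. Among the compounds with values here, no step between measured compounds is known; from this change no movement beyond the scatter is expected, and a further limit is likely. The expected step is a number no higher from compound 2 to compound 3 (the limit leaves the size open). Compound 3 is estimated at 30000 nM, within a range from 6000 nM to 150000 nM.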

Compound 3, half-maximal inhibitory concentration: > 30000 nM
Compound 3 gave a limit, no number; the forecaster's own chance of this, stated with the estimate: 70%; the middle value lies on the limit itself.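

Compound 2 and compound 3 both end at a limit, so no step between them can be read: the limit of > 30000 nM in this assay, at which 2 of the 3 values shown sit.

The compounds shown leave open whether any group at this place on the shared core gives a number rather than a limit.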